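Cyclobutanol diastereomer in the metabolic stability series

A few compounds are considered here, and "the series" means these few. Any claim that something is new, unique, unknown or untested is made for them only; others in the source may bear on it.

Compound 1 `O[C@H](c1ccccn1)[C@]1(c2ccc(C(F)(F)F)cc2)C[C@@H](O)C1` is the reference point of this set. In an ADME assay on liver for metabolic stability, with Liver microsome (Rattus norvegicus) as the target, read by LC-MS, using microsomes, with a stated time of 5 h (a higher number here means faster removal of the compound, a lower number slower removal), compound 1 gives 50 mL/min/kg, the lowest of the three numbers measured. Its nearest neighbour, compound 3 `C[C@]1(O)C[C@@](c2ccc(C(F)(F)F)cc2)([C@H](O)c2ccccn2)C1`, gives 150 mL/min/kg in this assay; the step of a 3.0-fold higher number from compound 1 to compound 3 (0.48 log units; beyond the scatter) comes from the methyl that enters on a saturated ring carbon. Furthest away is compound 2 `O[C@H](c1ncccn1)C1(c2ccc(Cl)c(Cl)c2)CCC1`, which gives 833 mL/min/kg in this assay; no single-change step links it to compound 1.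

Compound 4 `O[C@H](c1ccccn1)[C@]1(c2ccc(C(F)(F)F)cc2)C[C@H](O)C1` is the next compound for this assay. How it differs from compound 1: the two compounds have the same atoms and bonds and differ only in configuration as drawn: 2 of 3 stereo elements differ; a stereocentre at a saturated ring carbon is drawn r in compound 1 and s in compound 4; a stereocentre at a saturated ring carbon is drawn S in compound 1 and R in compound 4. Among the compounds with values here, none of the measured steps involves a change of configuration alone, so there is no measured step that bears directly on this one; the only step available, from compound 1 to compound 3, concerns an added methyl rather than a change of configuration as drawn. The expectation is therefore a step of no change at the digits printed from compound 1 to compound 4 (within the scatter) that stays within the scatter, in no particular direction. Compound 4 is estimated at 50 mL/min/kg in this assay, with a range from 20 mL/min/kg to 150 mL/min/kg.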

Compound 4, clearance: 50 mL/min/kg
For compound 4 middle estimate and measured number coincide at the digits printed, and the stated range covers the measured number.
By their numbers in this assay, from the lowest: compounds 1 and 4 (each within the scatter of the next); then compound 3; then compound 2.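

In this assay, within the data shown here, the change of configuration alone gives no change at the digits printed from compound 1 to compound 4 (within the scatter), the first measured step of this kind on the shared core. For this pair, the drawn configuration at the two saturated ring carbons therefore leaves the number unmoved, whereas the added methyl gives a 3.0-fold higher number from compound 1 to compound 3 (0.48 log units; beyond the scatter). The comparison is clean in structure, with nothing entering or leaving: the fact that compounds 1 and 4 differ only in the configuration as drawn

From the compounds shown here alone, whether the methyl step keeps its size on the configuration of compound 4 remains open, since only the configuration of compound 1 carries a measured methyl step. Also open, going by these compounds, is how the number responds when the ring hydroxyl gives way to an amine or a carboxylic acid, and whether the two configurations stay level with such groups in place.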